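The source may hold more compounds than are shown below. What is called first, only, known or untested is meant among the compounds shown, and "the series" means these compounds.

Measured so far:
- compound 1, `C[C@H](Nc1nc(N)nc(N)c1C#N)c1cc2ccc(F)cn2c(=O)c1-c1ccccc1`: 691000 nM
- compound 2, `C[C@H](Nc1nc(N)nc(N)c1C#N)c1cc(=O)n2cc(F)ccc2c1-c1cc(F)cc(F)c1`: 368000 nM

In a physicochemical assay for solubility (a lower number here means a less soluble compound, a higher number a more soluble compound), compound 1 gives 691000 nM, the highest of the two numbers recorded, and compound 2 gives 368000 nM. The gap between these two values lies within the scatter of repeated measurements, so the numbers do not separate the two compounds.

Compound 3, `C[C@H](Nc1nc(N)nc(N)c1C#N)c1c(-c2ccccc2)c(=O)n2cc(F)ccc2c1-c1ccccc1`, has not yet been measured in this assay. It differs from compound 1 in one place: phenyl in place of hydrogen on an aromatic carbon. Going by the values given here, no pair of measured compounds shows a step of this kind, so there is no measured step to lean on, and the expectation rests on the structural change alone. The expected step is a 6.9-fold lower number from compound 1 to compound 3 (0.84 log units; beyond the scatter), a fall in solubility beyond the scatter rather than a change within it. Compound 3 is therefore estimated to give 100000 nM in this assay, with a range from 30000 nM to 300000 nM.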

Compound 3, solubility: 50600 nM
For compound 3 the middle estimate is 2.0-fold (0.30 log units) above the measured one; the measured number falls inside the stated range.
By their numbers in this assay, from the lowest: compound 3; then compounds 2 and 1 (each within the scatter of the next).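

In this assay, phenyl in place of hydrogen on this aromatic carbon gives a 14-fold lower number from compound 1 to compound 3 (1.14 log units; beyond the scatter), a large step beyond the scatter. Going by these compounds alone, compounds 1 and 2 alone showed no step at any position, so this is the first sign that the number responds to a change at this carbon, on the carbon ortho to a fused ring and two atoms from the ring nitrogen. Nothing measured here says why the number falls so far.

Going by these compounds, only phenyl has been seen at this carbon, so it remains open whether a methyl, an amine or a carboxylic acid in the same place would give a step of similar size. On these data alone, it is also open whether phenyl would give the same step on the core of compound 2.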